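Swapping the group on sulfur: compound 3 to compound 4

The source may hold more compounds than are shown below. What is called first, only, known or untested is meant among the compounds shown, and "the series" means these compounds.

compound 1 `COc1ccc(SCc2ccc(/C=C/C(=O)Nc3ccccc3N)cc2)cc1OC`: 46%
compound 2 `Cc1cc(C)cc(SCc2ccc(/C=C/C(=O)Nc3ccccc3N)cc2)c1`: 8.78%
compound 3 `CCc1ccc(SCc2ccc(/C=C/C(=O)Nc3ccccc3N)cc2)cc1`: 5.27%

These readings come from a functional assay on A-375 cells (Homo sapiens) for inhibition, read by CCK-8 assay, with a stated time of 72 h, tested at 2 uM; a lower number here means less inhibition of growth, a higher number more inhibition of growth at the concentration tested. Compound 3 cannot be told apart from its closest neighbour, as a number 3.5 percentage points lower from compound 2 to compound 3 (within the scatter) shows, and it lies far under the top reading, with a number 40.7 percentage points lower from compound 1 to compound 3 (beyond the scatter). Compound 4 `Nc1ccccc1NC(=O)/C=C/c1ccc(CSc2ccc(C(F)(F)F)cn2)cc1` alters only the group on the sulfur: 5-(trifluoromethyl)pyridin-2-yl in place of 4-ethylphenyl on a sulfur. The measured steps all swap this same group. Two are large, a number 37.2 percentage points lower from compound 1 to compound 2 (beyond the scatter) and a number 40.7 percentage points lower from compound 1 to compound 3 (beyond the scatter), so this group can matter, yet neither includes the incoming group, which leaves the direction poorly fixed. Only compound 1 reads high, at 46%, so a small upward step is expected rather than a large one. The estimated step is a number 7.7 percentage points higher from compound 3 to compound 4 (within the scatter). For compound 4 the estimate is 13%, with an expected range from 2% to 40%.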

Compound 4, percent growth inhibition at one concentration: 10.3%
Estimate against measurement, compound 4: 2.7 percentage points above; the measured number falls inside the stated range.
By their numbers in this assay, from the lowest: compounds 3, 2 and 4 (each within the scatter of the next); then compound 1.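

Compound 4 puts a ring with a hetero atom and a hydrogen-bond acceptor on the sulfur, yet in this assay it cannot be told apart from the two alkyl-substituted phenyl compounds, with a number 5 percentage points higher from compound 3 to compound 4 (within the scatter) and a number 1.5 percentage points higher from compound 2 to compound 4 (within the scatter). Only the 3,4-dimethoxyphenyl group stands apart, with a number 35.7 percentage points lower from compound 1 to compound 4 (beyond the scatter), leaving compound 1 alone at the top of these four. No measurement shown accounts for this difference.

Open, as far as these compounds go, is whether a single methoxy group on the phenyl ring would keep the reading of compound 1. So too is whether a hydroxyl group or an amine in place of the methoxy groups would keep it.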